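The compounds below may be only part of what the source reports. "The series", "measured", "known", "first", "only" and "open" are said of these compounds alone.

Series notes. In an ADME assay on LLC-MK2 cells (Macaca mulatta) for cytotoxicity, read by spectrophotometry and crystal violet staining, with a stated time of 4 days (on this read-out higher numbers stand for lower toxicity in this test and lower numbers for higher toxicity in this test), compound 3 `CC(C)n1ncc2c(C(=O)Nc3ccccc3F)cc(-c3cccs3)nc21` gives 50000 nM, level at the digits shown with compound 1 `CC(C)n1ncc2c(C(=O)Nc3ccccc3F)cc(-c3cccnc3)nc21`, which gives 50000 nM; together these are the highest of the three numbers. Compound 2 `CC(C)n1ncc2c(C(=O)Nc3cccc(S(N)(=O)=O)c3)cc(-c3cccs3)nc21` gives 25000 nM, and the step of a 2.0-fold higher number from compound 2 to compound 3 (0.30 log units; within the scatter) stays within the scatter. Compound 4 `CC(C)n1ncc2c(C(=O)Nc3ccccc3F)cc(-c3ccccc3)nc21` differs from compound 3 by phenyl in place of thiophen-2-yl on an aromatic carbon. Among the compounds with values here, the one measured step at this same position, no change at the digits printed from compound 1 to compound 3 (within the scatter), bears directly on the change and was flat within the scatter, so no step beyond the scatter is expected in this assay for the exchange to phenyl. Compound 4 is therefore estimated at 50000 nM, with a range of 25000 nM to 100000 nM, which is expected to correspond to a step of no change at the digits printed from compound 3 to compound 4 (within the scatter).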

Compound 4, half-maximal cytotoxic concentration: > 200000 nM
Compound 4: only a limit was reported; the forecaster's own chance of this, stated with the estimate: 20%; middle value at least 4.0-fold (0.60 log units) from the limit.
By their numbers in this assay, from the lowest: compounds 2, 1 and 3 (each within the scatter of the next). At a limit, above all of these: compound 4.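

In this assay, this position is no longer flat: the exchange for phenyl gives an at least 4.0-fold higher number from compound 3 to compound 4 (0.60 log units; beyond the scatter) and an at least 4.0-fold higher number from compound 1 to compound 4 (0.60 log units; beyond the scatter), whereas thiophen-2-yl and pyridin-3-yl gave no change at the digits printed from compound 1 to compound 3 (within the scatter). Among these three groups, only the ring of carbon only stands apart from the other two. The reading for compound 4 is a limit of the assay, not a number: the limit of > 200000 nM in this assay, at which 1 of the 4 values shown sits.

Going by these compounds, the true size of both steps stays open, as does whether phenyl has the same effect alongside the amide group of compound 2. On these data alone, whether a methoxyphenyl group or a saturated amine such as piperidine at this carbon would follow phenyl also remains open.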